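The source may hold more compounds than are shown below. What is called first, only, known or untested is meant among the compounds shown, and "the series" means these compounds.

Measured compounds:
- compound 1, `CCCCc1c(-c2ccc(O)c(O)c2)oc2cc(O)cc(O)c2c1=O`: 61800 nM
- compound 2, `O=c1cc(/C=C/c2ccc(O)c(O)c2)oc2c(O)c(O)ccc12`: 4690 nM

Among the compounds with values here, the two compounds measured so far were tested in a functional assay, read by fluorescence; a lower number here means a stronger inhibitor, a higher number a weaker inhibitor. Compound 1 gives 61800 nM, and compound 2 gives 4690 nM. Of the two numbers, compound 1 has the higher one, and the gap to compound 2 lies beyond the usual scatter of repeated measurements, so compound 1 stands as the weaker inhibitor of the pair.

Compound 3, `CCCCCCCCCCc1c(-c2ccc(O)c(O)c2)oc2cc(O)cc(O)c2c1=O`, has not yet been measured in this assay. It differs from compound 1 in one place: hexyl in place of hydrogen on a saturated chain carbon, four bonds along the chain from an aromatic carbon. Both compounds share the same core, and the change is confined to the saturated chain.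

Within the data shown here, no step between measured compounds bears on this change, so nothing measured shows how lengthening the chain by a hexyl affects this assay. Among the measured compounds shown here, with only the single anchor of compound 1 at 61800 nM, a modest shift is expected, most likely within or only slightly beyond the scatter, with a slight lean toward a lower number. Compound 3 is therefore estimated at 40000 nM, within the range 10000 nM to 150000 nM, which corresponds to an expected step of a 1.5-fold lower number from compound 1 to compound 3 (0.19 log units; within the scatter).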

Compound 3, half-maximal inhibitory concentration: 7900 nM
Estimate against measurement, compound 3: 5.1-fold (0.70 log units) above; the whole stated range lies above it.
By their numbers in this assay, from the lowest: compounds 2 and 3 (each within the scatter of the next); then compound 1.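

In this assay, hexyl in place of hydrogen on a saturated chain carbon, four bonds along the chain from an aromatic carbon, gives a 7.8-fold lower number from compound 1 to compound 3 (0.89 log units; beyond the scatter) and so moves the number by more than the scatter. Within the data shown here, this is the first measured change at this position, and it shows that the saturated chain is not a silent part of the molecule: with the shared core left as it is, lengthening the chain alone yields a stronger inhibitor. The compounds shown offer no measurement that would explain this step.

Going by these compounds, with only these two chain lengths to compare, it remains open whether the number falls steadily as the chain grows, whether most of the step is already reached at a shorter chain, or whether a still longer chain would continue the trend or reverse it. On these data alone, it is equally open whether the step depends on a plain carbon chain at all, or whether a chain carrying an amine, a carboxylic acid or a phenyl ring would behave in the same way.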